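From compound 2 to compound 3: an ester swap

The source may report more compounds than this note shows. Statements on the series, on what has been measured and on what is new or still open speak of the compounds shown alone.

Compound 1 `O=C(O)CCCOc1cccc(/C=C/c2ccc3cc(Cl)ccc3n2)c1`: 1.5 mg/kg
Compound 2 `COC(=O)COc1cccc(/C=C/c2ccc3ccccc3n2)c1`: 2 mg/kg

In a functional assay on the whole organism for inhibition, with Rattus norvegicus as the target, with a stated time of 5 min (on this read-out lower numbers stand for an effect already at smaller amounts and higher numbers for an effect only at larger amounts of compound), compound 2 gives 2 mg/kg and compound 1 gives 1.5 mg/kg, two numbers within the usual scatter of each other. Compound 3 `CCOC(=O)CCCOc1cccc(/C=C/c2ccc3ccccc3n2)c1` departs from compound 2 in one place: 2-(ethoxycarbonyl)ethyl in place of methoxycarbonyl on a saturated chain carbon bound to an oxygen on an aromatic ring, with 2-(ethoxycarbonyl)ethyl in place of methoxycarbonyl on a saturated chain carbon bound to an oxygen on an aromatic ring. Among the measured compounds shown here, no measured pair shows what such a change does in this assay, so no shift beyond the scatter is expected. The estimated step is a 1.3-fold higher number from compound 2 to compound 3 (0.10 log units; within the scatter). For compound 3 the expected value is 2.5 mg/kg, with an estimated range of 0.8 mg/kg to 8 mg/kg.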

Compound 3, dose for half-maximal effect: 1.5 mg/kg
Compound 3: middle estimate off by 1.7-fold (0.22 log units), on the high side; low and high end bracket the measured number.
By their numbers in this assay, from the lowest: compounds 1, 3 and 2 (each within the scatter of the next).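

In this assay the change gives a 1.3-fold lower number from compound 2 to compound 3 (0.12 log units; within the scatter) and so shows that this position accepts 3-(ethoxycarbonyl)propoxy in place of (methoxycarbonyl)methoxy with no shift that can be told from scatter. Both the length of the chain and the kind of ester change in this one step, so neither can be read alone. Nothing at hand explains the result.

Still open, on these data alone, is how a carboxylic acid on this chain would read on the core of compound 2, without the chlorine of compound 1. As far as these compounds go, an amine in place of the ester is equally open.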